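A few compounds are considered here, and "the series" means these few. Any claim that something is new, unique, unknown or untested is made for them only; others in the source may bear on it.

Compound 1 `Cc1ccc(-c2csc(N3C(=O)c4ccccc4C3=O)n2)cc1`, compound 2 `COc1ccc(-c2csc(N3C(=O)c4ccccc4C3=O)n2)cc1` and compound 3 `Cc1ccc(-c2csc(N3C(=O)c4ccc(F)cc4C3=O)n2)cc1` have all been tested in a functional assay on PC-3 cells (Homo sapiens) for antiproliferative activity, read by MTT assay, with a stated time of 48 h; on this read-out higher numbers stand for weaker inhibition and lower numbers for stronger inhibition. Compound 1 gives 38400 nM, compound 2 gives 42900 nM, and compound 3 gives 44400 nM, so all three half-maximal inhibitory concentrations lie close together.

Compound 2 differs from compound 1 by methoxy in place of methyl on an aromatic carbon, and that change made a step of a 1.1-fold higher number from compound 1 to compound 2 (0.05 log units; within the scatter). Compound 3 differs from compound 1 in its core by fluoro in place of hydrogen on an aromatic carbon, a step of a 1.2-fold higher number from compound 1 to compound 3 (0.06 log units; within the scatter). Compound 4 `COc1ccc(-c2csc(N3C(=O)c4ccc(F)cc4C3=O)n2)cc1` has not yet been measured in this assay. It differs from compound 3 by methoxy in place of methyl on an aromatic carbon, which is the same change already seen between compound 1 and compound 2, now made on the core of compound 3.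

Because the earlier step was a 1.1-fold higher number from compound 1 to compound 2 (0.05 log units; within the scatter), and because the change of core was a 1.2-fold higher number from compound 1 to compound 3 (0.06 log units; within the scatter), only a small move is expected this time. For compound 4 the expected step is a 1.1-fold higher number from compound 3 to compound 4 (0.03 log units; within the scatter). In this assay compound 4 is estimated at 48000 nM, with the likely range running from 25000 nM to 95000 nM.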

Compound 4, half-maximal inhibitory concentration: 41300 nM
For compound 4 the middle estimate is 1.2-fold (0.07 log units) above the measured one; measured number inside the range.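

Methoxy in place of methyl on the core that carries the fluoro gave a 1.1-fold lower number from compound 3 to compound 4 (0.03 log units; within the scatter) in this assay, and this step matches the earlier one on the other core: the same change on two cores in this assay, a 1.1-fold higher number (0.05 log units; within the scatter) from compound 1 to compound 2 and a 1.1-fold lower number (0.03 log units; within the scatter) from compound 3 to compound 4, 1.2-fold (0.08 log units) apart, within the scatter of two such steps

Fluoro in place of hydrogen, with 4-methoxyphenyl now in place of 4-methylphenyl, gave a 1.0-fold lower number from compound 2 to compound 4 (0.02 log units; within the scatter), and this step also matches its earlier counterpart: the same change on two cores in this assay, a 1.2-fold higher number (0.06 log units; within the scatter) from compound 1 to compound 3 and a 1.0-fold lower number (0.02 log units; within the scatter) from compound 2 to compound 4, 1.2-fold (0.08 log units) apart, within the scatter of two such steps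

So within this small set, neither change moves the number beyond the scatter on either core, and each carries across in that limited sense. This does not show that the two changes add up. Steps this small cannot separate a true additive effect from no effect at all, and the set says nothing about cores beyond these.

The compounds shown leave open whether a different group in the place of the methoxy, such as an amine, a carboxylic acid or a longer chain, would shift the number beyond the scatter. They also leave open whether chloro in place of the fluoro would do so.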